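Carbamoyl in place of methyl on the fused ring

The source may report more compounds than this note shows. Statements on the series, on what has been measured and on what is new or still open speak of the compounds shown alone.

Compound 1 `CN(C)C(=O)c1cnc2ccccc2c1NCCCN1CCN(c2ccccc2OCC(F)(F)F)CC1` and compound 2 `COc1cc(F)ccc1N1CCN(CCCNc2c(C(=O)N(C)C)cnc3c(C)cccc23)CC1` share one core. In a functional assay for antagonist activity at Alpha-1A adrenergic receptor (Oryctolagus cuniculus) (a higher number here means weaker binding, a lower number tighter binding), compound 1 gives 3.98 nM, and compound 2 gives 7.94 nM; compound 2 stands at the larger of the two numbers, though its gap to compound 1 lies within the scatter. Compound 3 `COc1cc(F)ccc1N1CCN(CCCNc2c(C(=O)N(C)C)cnc3c(C(N)=O)cccc23)CC1` differs from compound 2 by carbamoyl in place of methyl on an aromatic carbon. Among the measured compounds shown here, no measured pair shows this change, so the expected step is a 1.3-fold higher number from compound 2 to compound 3 (0.10 log units; within the scatter), none beyond the scatter. For compound 3 the estimate in this assay is 10 nM, with a range from 3 nM to 40 nM.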

Compound 3, dissociation constant: 0.501 nM
Estimate against measurement, compound 3: 20-fold (1.30 log units) above; measured number outside the range, below it.
By their numbers in this assay, from the lowest: compound 3; then compounds 1 and 2 (each within the scatter of the next).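

In this assay, carbamoyl in place of methyl on an aromatic carbon gives a 16-fold lower number from compound 2 to compound 3 (1.20 log units; beyond the scatter), so what this position carries can matter a great deal. Compound 1 and compound 2 differ in more than one place and offered no such reading of a single position. No measurement at hand accounts for the size of this step. The compounds shown leave open how a carboxylic acid, a nitrile or an aminomethyl group would behave on this aromatic carbon. They also leave open whether carbamoyl would give a similar step in the setting of compound 1.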